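Swapping dimethoxy for dichloro on the aniline ring

The source may hold more compounds than are shown below. What is called first, only, known or untested is meant among the compounds shown, and "the series" means these compounds.

Of the compounds shown here, three sharing one core have been tested in a functional assay on A549 cells (Homo sapiens) for cytotoxicity, read by MTT assay, with a stated time of 48 h; on this read-out higher numbers stand for weaker inhibition and lower numbers for stronger inhibition. Compound 1 `Cc1ccc(S(=O)(=O)/N=C(/CCNC2=CC(=O)c3ccccc3C2=O)Nc2ccc(F)cc2)cc1` gives 9330 nM, compound 2 `COc1ccc(N/C(CCNC2=CC(=O)c3ccccc3C2=O)=N\S(=O)(=O)c2ccc(C)cc2)cc1OC` gives 20500 nM, and compound 3 `COc1ccc(N/C(CCNC2=CC(=O)c3ccccc3C2=O)=N\S(=O)(=O)c2ccc(C)cc2)c(OC)c1` gives 126000 nM, the highest number of the three, as seen in a 14-fold higher number from compound 1 to compound 3 (1.13 log units; beyond the scatter) and a 6.1-fold higher number from compound 2 to compound 3 (0.79 log units; beyond the scatter). Compound 4 `Cc1ccc(S(=O)(=O)/N=C(/CCNC2=CC(=O)c3ccccc3C2=O)Nc2ccc(Cl)cc2Cl)cc1` differs from compound 3 by 2,4-dichlorophenyl in place of 2,4-dimethoxyphenyl on an amine nitrogen. Among the compounds with values here, no measured step covers this exact change. The closest guide is compound 1, whose 4-fluorophenyl group gives the lowest number, while a 2.2-fold higher number from compound 1 to compound 2 (0.34 log units; beyond the scatter) shows methoxy groups raising the number. The number for compound 4 is therefore expected to fall, with a 6.3-fold lower number from compound 3 to compound 4 (0.80 log units; beyond the scatter) as the estimated step. Compound 4 is expected at 20000 nM, within 5000 nM to 80000 nM, in this assay.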

Compound 4, half-maximal inhibitory concentration: 32900 nM
For compound 4 the middle estimate is 1.6-fold (0.22 log units) below the measured one; low and high end bracket the measured number.
By their numbers in this assay, from the lowest: compound 1; then compounds 2 and 4 (each within the scatter of the next); then compound 3.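

Putting 2,4-dichlorophenyl in place of 2,4-dimethoxyphenyl on the amine nitrogen gives a 3.8-fold lower number from compound 3 to compound 4 (0.58 log units; beyond the scatter) and so the high number of compound 3 does not belong to every group with substituents at these two ring places. The step of a 1.6-fold higher number from compound 2 to compound 4 (0.21 log units; within the scatter) leaves the dichloro compound level with the 3,4-dimethoxyphenyl compound. The step of a 3.5-fold higher number from compound 1 to compound 4 (0.55 log units; beyond the scatter) shows that it still does not reach the 4-fluorophenyl compound.

Going by these compounds, whether a 4-chlorophenyl or an unsubstituted phenyl group would come closer to compound 1 stays open. Nothing measured here gives a reason for these steps.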